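This account rests on a few compounds, and the source may have more. Where it says the series, first, only, none or still open, it means among the compounds named here.

Measured compounds:
compound 1, `CCCCCCNC(=O)Oc1ccc(Cl)cc1C(=O)Nc1ccc(Cl)cc1`, 43 h in an ADME assay for metabolic stability, read by HPLC, at pH 7.4; a lower number here means that the compound disappears faster, a higher number that the compound lasts longer
compound 2, `CCCCCCCNC(=O)Oc1ccc(Cl)cc1C(=O)Nc1ccc(Cl)cc1`, 43 h in this assay
compound 3, `CCCCCCCCCNC(=O)Oc1ccc(Cl)cc1C(=O)Nc1ccc(Cl)cc1`, 43 h in this assay

Compounds 1, 2 and 3 share one core and differ only in the length of the saturated chain. From compound 1 to compound 2 the change is methyl in place of hydrogen on a saturated chain carbon, six bonds along the chain from an amide-type nitrogen, and the step it made is no change at the digits printed from compound 1 to compound 2 (within the scatter). From compound 2 to compound 3 the step is no change at the digits printed from compound 2 to compound 3 (within the scatter), and across the whole span no change at the digits printed from compound 1 to compound 3 (within the scatter). Nothing in this small set moves the half-life.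

Compound 4 is `CCCCCCCCCCNC(=O)Oc1ccc(Cl)cc1C(=O)Nc1ccc(Cl)cc1`, not yet measured. Against compound 3 it differs by methyl in place of hydrogen on a saturated chain carbon, nine bonds along the chain from an amide-type nitrogen. The core of compound 3 differs from that of compound 1 by propyl in place of hydrogen on a saturated chain carbon, six bonds along the chain from an amide-type nitrogen. The change from compound 3 to compound 4 is the same kind of change as that from compound 1 to compound 2, not the same: there the methyl enters six bonds along the chain from an amide-type nitrogen, here nine bonds along the chain from an amide-type nitrogen.

The step from compound 3 to compound 4 in this assay is expected to be no change at the digits printed from compound 3 to compound 4 (within the scatter), because no change at the digits printed from compound 1 to compound 2 (within the scatter) and no change at the digits printed from compound 2 to compound 3 (within the scatter) show chain lengthening leaving the half-life unchanged. Compound 4 is estimated at 43 h, between 22 h and 86 h.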

Compound 4, half-life: 43 h
For compound 4 middle estimate and measured number coincide at the digits printed; measured number inside the range.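

In this assay the methyl change reads no change at the digits printed from compound 3 to compound 4 (within the scatter), and it carries from the core of compound 1 to the core of compound 3 without a difference: the same change on two cores in this assay, no change at the digits printed (within the scatter) from compound 1 to compound 2 and no change at the digits printed (within the scatter) from compound 3 to compound 4, 1.0-fold (0.00 log units) apart, within the scatter of two such steps The wider steps read no change at the digits printed from compound 2 to compound 4 (within the scatter) and no change at the digits printed from compound 1 to compound 4 (within the scatter), and the propyl change carries over in the same way: the same change on two cores in this assay, no change at the digits printed (within the scatter) from compound 1 to compound 3 and no change at the digits printed (within the scatter) from compound 2 to compound 4, 1.0-fold (0.00 log units) apart, within the scatter of two such steps This agreement holds only for these saturated chains on the shared core, and with every step flat it shows only that none of these additions moves the half-life, not that a change with a readable effect would transfer from one core to another.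

Still open, from the compounds shown here alone, is whether a shorter chain, a much longer chain, a branched chain or a chain ending in an amine or a carboxylic acid would stay level in this assay. Also open, going by these compounds, is how the half-life responds when something other than the chain changes, such as a chlorine on the shared core replaced by fluorine or a methoxy group.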